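The compounds below may be only part of what the source reports. "The series", "measured", "known", "first", "only" and "open" are said of these compounds alone.

Compound 2 `Clc1cccc(-c2c[nH]c3ncnc(N4CCCCC4)c23)c1` and compound 1 `CC1(O)CCN(c2ncnc3[nH]cc(-c4cccc(Cl)c4)c23)CC1` share one core and differ only in the group attached to it. In an assay for inhibition of serine/threonine-protein kinase 3 (Homo sapiens), read by luminescence and ADP-Glo, in the presence of a further agent that is not named here (on this read-out higher numbers stand for weaker inhibition and lower numbers for stronger inhibition), compound 1 gives 189 nM, and in this assay compound 2 gives 167 nM. The step of a 1.1-fold lower number from compound 1 to compound 2 (0.05 log units; within the scatter) shows that trading the hydroxylated, methylated ring of compound 1 for a plain piperidin-1-yl changed little. Compound 2 therefore holds the lower of the two numbers, but since its gap to compound 1 is within the scatter, neither can be called the more potent.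

Compound 3 `CC(CO)CN(C)c1ncnc2[nH]cc(-c3cccc(Cl)c3)c12` goes further: a group of 7 heavy atoms (5 carbon, 1 nitrogen, 1 oxygen; no ring) in place of a group of 6 heavy atoms (5 carbon, 1 nitrogen; one six-membered non-aromatic ring with 1 hetero atom), on an aromatic carbon. The ring is opened into a chain that carries a hydroxyl, so a hydrogen-bond donor and a second acceptor return, this time without the ring.

Among the compounds with values here, only the step from compound 1 to compound 2 bears on this, and it was within the scatter; it says that a hydroxyl at this site is tolerated, but it says nothing about losing the ring. A small step is therefore expected, with the direction uncertain and a slight lean toward a higher number, so compound 3 is expected to give 300 nM, between 100 nM and 900 nM, an expected step of a 1.8-fold higher number from compound 2 to compound 3 (0.25 log units; within the scatter).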

Compound 3, half-maximal inhibitory concentration: 58 nM
Beside the measured number, compound 3's estimate is 5.2-fold (0.71 log units) above it, outside the stated range (below it).
By their numbers in this assay, from the lowest: compound 3; then compounds 2 and 1 (each within the scatter of the next).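

Within the data shown here, replacing the ring with an open chain is the first change at this position on the shared core to move the number beyond the scatter. The result is a 2.9-fold lower number from compound 2 to compound 3 (0.46 log units; beyond the scatter) and a 3.3-fold lower number from compound 1 to compound 3 (0.51 log units; beyond the scatter) in this assay and this makes compound 3 the strongest inhibitor of the three, although both steps are modest. The six-membered ring of compound 1 and compound 2 is therefore not needed for inhibition in this small set, and a chain bearing a hydroxyl is tolerated here at least as well as either ring; nothing available explains why the number falls with this change.

As far as these compounds go, whether the lower number belongs to the opening of the ring or to the hydroxyl on the chain remains open, as the two changes arrive together in compound 3, and the same chain ending in a plain methyl group in place of the hydroxyl-bearing carbon would help to separate them. Also open, from the compounds shown here alone, is how a chain ending in an amine or a carboxylic acid, or a longer chain ending in a hydroxyl, would read at this position.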